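A few compounds are considered here, and "the series" means these few. Any claim that something is new, unique, unknown or untested is made for them only; others in the source may bear on it.

Compound 1 `Cc1cc(Cl)nnc1N1CCN(c2ncccn2)CC1` gives in a functional assay on BV-2 cells (Mus musculus) for inhibition, read by ELISA, with a stated time of 16 h (on this read-out lower numbers stand for stronger inhibition and higher numbers for weaker inhibition), a result of > 100000 nM, which is a limit of the assay rather than a number.
Compound 2 `Cc1cc(C(C)C)nnc1N1CCN(c2ncccn2)CC1` gives in this assay a result of > 100000 nM, again a limit and not a number.
Compound 3 `Cc1cc(-c2ccsc2)nnc1N1CCN(c2ncccn2)CC1` gives in this assay a value of 2400 nM.

Compound 3 therefore stands apart as the only one of the three with a measured number; the other two results sit at the limit of > 100000 nM in this assay, at which 2 of the 3 values shown sit. Compound 4 `Cc1cc(-c2cccnc2)nnc1N1CCN(c2ncccn2)CC1` differs from compound 3 in a single place: pyridin-3-yl in place of thiophen-3-yl on an aromatic carbon. Two measured steps lead to compound 3, namely an at least 41-fold lower number from compound 1 to compound 3 (1.61 log units; beyond the scatter) and an at least 41-fold lower number from compound 2 to compound 3 (1.61 log units; beyond the scatter), and both show that a five-membered aromatic ring at this position, in place of a chloro or isopropyl group, brings a large gain. The step that the two limits leave unreadable from compound 1 to compound 2 adds nothing readable. None of these steps exchanges one aromatic ring for another, so they give no direct measure for the move from thiophen-3-yl to pyridin-3-yl. Since an aromatic ring carrying one hetero atom and one hydrogen-bond acceptor stays in place, only a modest shift is expected, most likely within or just beyond the scatter. The expected step is a 1.7-fold higher number from compound 3 to compound 4 (0.22 log units; within the scatter). Compound 4 is thus estimated at 4000 nM in this assay, within a range from 1000 nM to 16000 nM.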

Compound 4, half-maximal inhibitory concentration: > 100000 nM
Compound 4: no number, only a limit (the forecaster's own chance of this, stated with the estimate: 10%); middle value at least 25-fold (1.39 log units) away from the limit.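

The earlier steps shown here showed only that thiophen-3-yl at this position gives a far lower number than chloro or isopropyl, and they said nothing about one aromatic ring against another. Exchanging thiophen-3-yl for pyridin-3-yl keeps one aromatic ring with 1 hetero atom and 1 hydrogen-bond acceptor, yet it gives an at least 41-fold higher number from compound 3 to compound 4 (1.61 log units; beyond the scatter), which shows that an aromatic ring here is not enough by itself and that the kind of ring matters, with thiophen-3-yl the only group among those shown that gives a number. Compound 4 gives a limit and not a number, and as compound 1 and compound 2 also give limits, the steps from those two to compound 4 cannot be read: the limit of > 100000 nM in this assay, at which 3 of the 4 values shown sit.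

Thiophen-3-yl and pyridin-3-yl differ in ring size and in hetero atom at the same time, and the compounds shown do not tell which of the two differences counts. As far as these compounds go, a phenyl ring or a furan-3-yl ring at this position would help to separate them, and how thiophen-2-yl or pyridin-4-yl would behave also remains open.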